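The source may report more compounds than this note shows. Statements on the series, on what has been measured and on what is new or still open speak of the compounds shown alone.

Two compounds share one core and differ only in the group on a side ring. Compound 1 `COc1cccc(S(=O)(=O)Nc2ccc3oc(-c4ccccc4)nc3c2)c1` carries a methoxy group there. In an assay on cells for inhibition of HSP60/HSP10 (Homo sapiens), with a stated time of 60 min (a lower number here means a stronger inhibitor, a higher number a weaker inhibitor), compound 1 gives only a limit of the assay, > 100000 nM. Compound 2 `O=S(=O)(Nc1ccc2oc(-c3ccccc3)nc2c1)c1cccc(Cl)c1` carries a chloro group in place of that methoxy. In this assay compound 2 also gives only a limit of the assay, > 100000 nM. The change of a step that the two limits leave unreadable from compound 1 to compound 2 therefore cannot be read as a number in either direction. Both values sit at the limit of > 100000 nM in this assay, at which 2 of the 2 values shown sit, so compound 2 stands with no measured number of its own, only that limit. Compound 3 `O=S(=O)(Nc1ccc2oc(-c3ccccc3)nc2c1)c1ccc(Cl)c(Cl)c1` takes the next step: chloro in place of hydrogen on an aromatic carbon. Within the data shown here, no measured step bears directly on this change, and the one step that exists could not be read, so nothing points toward a gain or a loss beyond the scatter. The step from compound 2 to compound 3 is therefore expected to be a number no higher from compound 2 to compound 3 (the limit leaves the size open), with a second limit the most likely outcome. Compound 3 is expected to give about 100000 nM in this assay, somewhere between 30000 nM and 300000 nM.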

Compound 3, half-maximal inhibitory concentration: > 100000 nM
Compound 3 was reported as a limit (the forecaster's own chance of this, stated with the estimate: 70%); the middle value lies on the limit itself.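

No step among compound 1, compound 2 and compound 3 can be read as a number, because all three give only the same limit: the limit of > 100000 nM in this assay, at which 3 of the 3 values shown sit.

The compounds shown leave open whether swapping these groups on the side ring changes inhibition at all, and how strongly any compound with this shared core inhibits in this assay.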